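Bromo in Place of Hydrogen: From Compound 2 to Compound 4

A few compounds are considered here, and "the series" means these few. Any claim that something is new, unique, unknown or untested is made for them only; others in the source may bear on it.

Of the compounds shown here, three have been measured in a physicochemical assay for lipophilicity; on this read-out higher numbers stand for higher lipophilicity and lower numbers for lower lipophilicity. Compound 1 `O=C(Nc1ccc(Cl)cc1)Nc1ccc(OC2=NS(=O)(=O)c3ccccc32)cc1` gives 3.55, compound 2 `O=C(Nc1ccccc1)Nc1ccc(OC2=NS(=O)(=O)c3ccccc32)cc1` gives 2.89, and compound 3 `CCOC(=O)C(=CNc1ccc2c(c1)C(Nc1cccc(Br)c1)=NS2(=O)=O)C(=O)OCC` gives 2.48. Compound 2 stands second highest of the three, with compound 3 nearest and compound 1 furthest. Compound 4 `O=C(Nc1ccc(Br)cc1)Nc1ccc(OC2=NS(=O)(=O)c3ccccc32)cc1` differs from compound 2 by bromo in place of hydrogen on an aromatic carbon. Among the measured compounds shown here, the one measured step that bears on this is a number 0.66 log units lower from compound 1 to compound 2 (beyond the scatter), the loss of a halogen from the same aromatic carbon. Reversing that step, with bromo entering instead of chloro, a rise of at least similar size is expected in this assay. Compound 4 is therefore expected to give 3.7, between 3.3 and 4.1. This estimate means a step of a number 0.81 log units higher from compound 2 to compound 4 (beyond the scatter), expected to lie beyond the scatter.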

Compound 4, partition coefficient: 3.64
For compound 4 the middle estimate is 0.06 log units above the measured one; the range from low to high includes it.
By their numbers in this assay, from the lowest: compound 3; then compound 2; then compounds 1 and 4 (each within the scatter of the next).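

In this assay, bromo in place of hydrogen gives a number 0.75 log units higher from compound 2 to compound 4 (beyond the scatter) and so shows that the rise at this aromatic carbon is not confined to chloro. Bromo in place of chloro gives a number 0.09 log units higher from compound 1 to compound 4 (within the scatter) and so leaves the two halogens not told apart at this position. There is no evidence that explains either step. The compounds shown leave open how a group other than a halogen, such as an amine or a carboxylic acid, would read at this carbon. They also leave open whether bromo would give a similar step on a different core.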